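Acetyl on the ring amine, carried to a second core

The compounds below may be only part of what the source reports. "The series", "measured", "known", "first", "only" and "open" are said of these compounds alone.

Measured so far:
compound 1 `Nc1n[nH]c2cc(-c3cn([C@@H]4CN[C@H](C(=O)Nc5ccc(Br)cc5)C4)nn3)ccc12`: 10300 nM
compound 2 `CC(=O)Nc1n[nH]c2cc(-c3cn([C@@H]4CN[C@H](C(=O)Nc5ccc(Br)cc5)C4)nn3)ccc12`: 3830 nM
compound 3 `Nc1nc2ccc(-c3cn([C@@H]4CN[C@H](C(=O)Nc5ccc(Cl)cc5Cl)C4)nn3)nc2s1`: 24500 nM

In a functional assay on K562 cells (Homo sapiens) for inhibition, read by MTT assay, with a stated time of 48 h (a higher number here means a weaker inhibitor, a lower number a stronger inhibitor), compound 1 gives 10300 nM and compound 2 gives 3830 nM. Compound 2 differs from compound 1 by acetyl in place of hydrogen on a nitrogen on an aromatic ring, and that change made a 2.7-fold lower number from compound 1 to compound 2 (0.43 log units; beyond the scatter). Compound 3 gives 24500 nM in this assay, the highest of the three numbers; the difference between the core of compound 3 and the core of compound 1 is not broken down here. Compound 4 `CC(=O)Nc1nc2ccc(-c3cn([C@@H]4CN[C@H](C(=O)Nc5ccc(Cl)cc5Cl)C4)nn3)nc2s1` is not yet measured. It differs from compound 3 by acetyl in place of hydrogen on a nitrogen on an aromatic ring, the same change as before, made on the second core. Because a 2.7-fold lower number from compound 1 to compound 2 (0.43 log units; beyond the scatter) was modest but beyond the scatter, a step of about a 2.5-fold lower number from compound 3 to compound 4 (0.39 log units; beyond the scatter) is expected here too in this assay. Compound 4 is therefore estimated at 10000 nM, between 4000 nM and 30000 nM.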

Compound 4, half-maximal inhibitory concentration: 9670 nM
Compound 4: the middle estimate sits 1.0-fold (0.01 log units) above what was measured; low and high end bracket the measured number.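

In this assay, acetyl in place of hydrogen on a nitrogen on an aromatic ring gives a 2.5-fold lower number from compound 3 to compound 4 (0.40 log units; beyond the scatter) on the second core, and the step keeps its size from one core to the other: the same change on two cores in this assay, a 2.7-fold lower number (0.43 log units; beyond the scatter) from compound 1 to compound 2 and a 2.5-fold lower number (0.40 log units; beyond the scatter) from compound 3 to compound 4, 1.1-fold (0.03 log units) apart, within the scatter of two such steps. Within the data shown here, this agreement rests on only two pairs, which differ both in the core and in the halogens on the anilide ring, so the separate contribution of each cannot be read. It shows that the step carries over in this cell assay, but not why it occurs or whether it would hold on any further core.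

As far as these compounds go, whether a longer acyl group such as propionyl, or a methanesulfonyl group, on the same nitrogen gives a similar step remains open. Also open, from the compounds shown here alone, is whether the step stays the same when both cores carry one anilide.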